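Chloro and fluoro placement: compound 2 to compound 3

The compounds below may be only part of what the source reports. "The series", "measured", "known", "first", "only" and "open" are said of these compounds alone.

Measured in an ADME assay on Vero cells (Chlorocebus sabaeus) for cytotoxicity, read by MTT assay, with a stated time of 72 h; on this read-out lower numbers stand for higher toxicity in this test and higher numbers for lower toxicity in this test:
compound 1 `C[C@]1(CN2CCc3nc(-c4ccc(F)c(F)c4)ccc3C2)Cn2cc([N+](=O)[O-])nc2O1`: > 32 ug/mL
compound 2 `C[C@]1(CN2CCc3nc(-c4ccc(F)c(Cl)c4)ccc3C2)Cn2cc([N+](=O)[O-])nc2O1`: > 32 ug/mL

Both entries are limits of the assay, not numbers. Compound 2 stands at the limit > 32 ug/mL. The series therefore offers no numerical value, and its whole record is the limit of > 32 ug/mL in this assay, at which 2 of the 2 values shown sit.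

Compound 3 `C[C@]1(CN2CCc3nc(-c4cc(Cl)ccc4F)ccc3C2)Cn2cc([N+](=O)[O-])nc2O1` carries 5-chloro-2-fluorophenyl in place of 3-chloro-4-fluorophenyl on an aromatic carbon, next to the ring nitrogen (5-chloro-2-fluorophenyl in place of 3-chloro-4-fluorophenyl on an aromatic carbon). The two structures have the same atoms, joined differently.

Among the measured compounds shown here, only one measured step bears on this change, and it is of a different kind, a swap of one atom rather than a rearrangement. That step, a step that the two limits leave unreadable from compound 1 to compound 2, gives no size to carry over. No step beyond the usual scatter is therefore expected in this assay, and no direction can be assigned. The most likely report is another limit.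

The estimated step is a step that the limit leaves unreadable from compound 2 to compound 3. Compound 3 is expected at 40 ug/mL, with an estimated range from 22 ug/mL to 70 ug/mL.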

Compound 3, half-maximal cytotoxic concentration: > 32 ug/mL
Compound 3 was reported as a limit (the forecaster's own chance of this, stated with the estimate: 85%); the middle value is on the limit's open side.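

In this assay compound 3 gives > 32 ug/mL, which is a limit and not a number. No new step can be read among compound 1, compound 2 and compound 3, whose shared record is: the limit of > 32 ug/mL in this assay, at which 3 of the 3 values shown sit. Still open, on these data alone, is where the half-maximal cytotoxic concentration of each compound lies, and whether the chloro and fluoro placement changes it.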